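Dimethoxybenzyl in place of tert-butylbenzyl on a sulfonamide chain

The source may hold more compounds than are shown below. What is called first, only, known or untested is meant among the compounds shown, and "the series" means these compounds.

Compound 1 `CC(C)(C)c1ccc(CNCCCNS(=O)(=O)c2cc(C(F)(F)F)cc(C(F)(F)F)c2)cc1` and compound 2 `O=S(=O)(NCCNCc1ccc(-c2ccccc2)cc1)c1cc(C(F)(F)F)cc(C(F)(F)F)c1` share a core. In a functional assay on DU-145 cells (Homo sapiens) for inhibition, read by MTT assay, with a stated time of 72 h (on this read-out higher numbers stand for weaker inhibition of growth and lower numbers for stronger inhibition of growth), compound 1 gives 2700 nM, the higher of the two numbers shown, though the gap to compound 2, which gives 2500 nM, lies within the scatter. Compound 3 `COc1ccc(CNCCCNS(=O)(=O)c2cc(C(F)(F)F)cc(C(F)(F)F)c2)cc1OC` has not yet been measured; it differs from compound 1 by 3,4-dimethoxyphenyl in place of 4-(tert-butyl)phenyl on a saturated chain carbon bound to an amine nitrogen. For the measured compounds named here, no measured pair shows this change, so the size of the step cannot be read from the data. Compound 3 is estimated at 3500 nM, with a range from 1200 nM to 10000 nM. This amounts to an expected step of a 1.3-fold higher number from compound 1 to compound 3 (0.11 log units; within the scatter), not clearly beyond the scatter.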

Compound 3, concentration for 50% growth inhibition: 4000 nM
The estimate for compound 3 lay 1.1-fold (0.06 log units) below the measured number; the range from low to high includes it.
By their numbers in this assay, from the lowest: compounds 2, 1 and 3 (each within the scatter of the next).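

In this assay, for the compounds shown here, the first direct reading of this change, 3,4-dimethoxyphenyl in place of 4-(tert-butyl)phenyl on a saturated chain carbon bound to an amine nitrogen, gives a 1.5-fold higher number from compound 1 to compound 3 (0.17 log units; within the scatter) and so shows no clear difference. Two hydrogen-bond acceptors thus enter at this position, with the same heavy-atom count, without a step beyond the scatter. Nothing available explains this result. Still open, going by these compounds, is whether a pyridine ring or a benzoic acid group in this place would move the number beyond the scatter.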